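Adding one carbon to the oxime acid arm of compound 3

The source may hold more compounds than are shown below. What is called first, only, known or untested is meant among the compounds shown, and "the series" means these compounds.

Compound 1 `CCCCC(CCCC)C(O/N=C(\C)C(=O)O)c1ccc(OCc2ccc3ccccc3n2)cc1`: 14 nM
Compound 2 `C/C(=N\OC(c1ccc(OCc2ccc3ccccc3n2)cc1)C1CCCC1)C(=O)O`: 16 nM
Compound 3 `O=C(O)/C=N/OC(CC1CCCCC1)c1ccc(OCc2ccc3ccccc3n2)cc1`: 27 nM

In a functional assay for inhibition of Polyunsaturated fatty acid 5-lipoxygenase (Homo sapiens) (a higher number here means a weaker inhibitor, a lower number a stronger inhibitor), compound 3 gives the highest of the three numbers, yet its gaps to compound 2 and to compound 1 both lie within the usual scatter of repeated measurements, so the three compounds cannot be told apart with confidence. Compound 4 `C/C(=N\OC(CC1CCCCC1)c1ccc(OCc2ccc3ccccc3n2)cc1)C(=O)O` differs from compound 3 in one place: a group of 6 heavy atoms (3 carbon, 1 nitrogen, 2 oxygen; no ring) in place of a group of 5 heavy atoms (2 carbon, 1 nitrogen, 2 oxygen; no ring), on an oxygen on a saturated carbon. The group that enters is the same arm already carried by compound 1 and compound 2. Going by the values given here, the only measured step, a 1.1-fold higher number from compound 1 to compound 2 (0.06 log units; within the scatter), concerns a different part of the molecule and does not bear on this change. Compound 1 and compound 2, which carry the entering arm, show somewhat lower numbers than compound 3, but they also differ from it elsewhere, so this offers weak guidance at best. A step no larger than the scatter is expected; the estimated step is a 1.4-fold lower number from compound 3 to compound 4 (0.15 log units; within the scatter). Compound 4 is thus expected to give about 19 nM in this assay, within a range from 8 nM to 45 nM.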

Compound 4, half-maximal inhibitory concentration: 29 nM
Beside the measured number, compound 4's estimate is 1.5-fold (0.18 log units) below it, and the stated range covers the measured number.
By their numbers in this assay, from the lowest: compounds 1, 2, 3 and 4 (each within the scatter of the next, the first and the last beyond it).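

In this assay, the arm on the oxygen can carry the extra carbon with almost no effect when cyclohexylmethyl is present, the step being a 1.1-fold higher number from compound 3 to compound 4 (0.03 log units; within the scatter). Going by these compounds alone, with that larger arm held fixed, the group on the saturated chain carbon is the only change in two further steps: a 1.8-fold higher number from compound 2 to compound 4 (0.26 log units; within the scatter) for cyclohexylmethyl in place of cyclopentyl, and a 2.1-fold higher number from compound 1 to compound 4 (0.32 log units; beyond the scatter) for cyclohexylmethyl in place of 1-butylpentyl, so only the second of these exceeds the scatter, and modestly. No supporting measurement is available to explain either the flat arm step or the modest one.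

On these data alone, the smaller arm appears only with cyclohexylmethyl, so it remains open whether the extra carbon matters as little with cyclopentyl or 1-butylpentyl. Also open, as far as these compounds go, is how a longer chain on the arm, or an amide in place of its carboxylic acid, would behave.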